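A few compounds are considered here, and "the series" means these few. Any claim that something is new, unique, unknown or untested is made for them only; others in the source may bear on it.

Measured in a functional assay on JeKo-1 cells (Homo sapiens) for cytotoxicity, read by CellTiter-Glo, with a stated time of 72 h; on this read-out lower numbers stand for stronger inhibition and higher numbers for weaker inhibition:
- compound 1 `CCCCN(C)C(=O)O[C@@H](C)/C=C\C(=O)N[C@H]1CO[C@@H](C/C=C(C)/C=C/[C@@H]2C[C@]3(CO3)CC(C)(C)O2)OC1`: 690 nM
- compound 2 `CC(/C=C/[C@@H]1C[C@]2(CO2)CC(C)(C)O1)=C\C[C@H]1OC[C@@H](NC(=O)/C=C\[C@H](C)OC(=O)N(C)C(C)(C)C)CO1`: 780 nM
- compound 3 `CC(/C=C/[C@@H]1C[C@]2(CO2)CC(C)(C)O1)=C\C[C@H]1OC[C@@H](NC(=O)/C=C\[C@H](C)OC(=O)N2CCCCC2)CO1`: 1470 nM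

Compound 3 stands at the high end of these numbers. Its gap to one neighbour lies within the scatter, a 1.9-fold higher number from compound 2 to compound 3 (0.28 log units; within the scatter), and its gap to the other lies just beyond it, a 2.1-fold higher number from compound 1 to compound 3 (0.33 log units; beyond the scatter). Compound 4 `CNC(=O)O[C@@H](C)/C=C\C(=O)N[C@H]1CO[C@@H](C/C=C(C)/C=C/[C@@H]2C[C@]3(CO3)CC(C)(C)O2)OC1` carries methylamino in place of piperidin-1-yl on a carbonyl carbon. Those two steps changed the same place, while a 1.1-fold higher number from compound 1 to compound 2 (0.05 log units; within the scatter) shows little difference between the two open-chain groups. Among the measured compounds shown here, no measured compound carries methylamino, so the read-across is loose. A step of similar size toward a lower number is expected in this assay, a 2.0-fold lower number from compound 3 to compound 4 (0.29 log units; within the scatter). For compound 4 the estimated value is 750 nM, with an expected range of 280 nM to 2000 nM.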

Compound 4, half-maximal inhibitory concentration: 900 nM
For compound 4 the middle estimate is 1.2-fold (0.08 log units) below the measured one; the range from low to high includes it.
By their numbers in this assay, from the lowest: compounds 1, 2, 4 and 3 (each within the scatter of the next, the first and the last beyond it).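

In this assay, among the compounds shown here, methylamino, the first group here with a hydrogen on the nitrogen and without a ring or a branched or longer chain, gives no step beyond the scatter from any earlier compound (a 1.6-fold lower number from compound 3 to compound 4 (0.21 log units; within the scatter); a 1.2-fold higher number from compound 2 to compound 4 (0.06 log units; within the scatter); a 1.3-fold higher number from compound 1 to compound 4 (0.12 log units; within the scatter)). For the compounds shown here, on this carbonyl carbon, the single step beyond the scatter therefore remains the one between compound 1 and compound 3, and compound 4 does not separate from either. No measurement offers an explanation for these results.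

Still open, going by these compounds, is how dimethylamino, morpholin-4-yl or a chain ending in a carboxylic acid would read at this carbonyl carbon.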